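A Second Chloro Added to the Core of Compound 2

The source may report more compounds than this note shows. Statements on the series, on what has been measured and on what is new or still open speak of the compounds shown alone.

Within the data shown here, compound 2 `ClCc1cccc(Cn2cnc3ncnc(Cl)c32)c1` is one of three compounds so far measured in a functional assay on MDA-MB-435 cells (Homo sapiens) for cytotoxicity, read by sulforhodamine B assay, with a stated time of 48 h; a lower number here means a stronger inhibitor of growth, a higher number a weaker inhibitor of growth. In this assay compound 2 gives 12900 nM. Compound 1 `ClCc1ccc(Cn2cnc3c(Cl)ncnc32)cc1` gives 4360 nM, and compound 3 `ClCc1ccc(Cn2cnc3c(Cl)nc(Cl)nc32)cc1` gives 25100 nM. Compound 2 therefore holds the second highest of the three numbers: its value lies within the scatter of the value of compound 3, while compound 1 sits a clear step lower, beyond the scatter.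

Compound 4 `ClCc1cccc(Cn2cnc3nc(Cl)nc(Cl)c32)c1` has not yet been measured in this assay. It differs from compound 2 by chloro in place of hydrogen on an aromatic carbon. Among the measured compounds shown here, one measured step bears directly on this change: the same exchange of hydrogen for chloro carried compound 1 into compound 3, and in that step a 5.8-fold higher number from compound 1 to compound 3 (0.76 log units; beyond the scatter). For the measured compounds named here, the two pairs share this change and differ only in the rest of the molecule, so the outcome for compound 4 is expected to follow the same direction, toward weaker growth inhibition, with a size of about the same order but with wide uncertainty, since only one such step is known.

Compound 4 is therefore expected to give 50000 nM in this assay, with a range from 15000 nM to 160000 nM. The expected step from compound 2 to compound 4 is a 3.9-fold higher number from compound 2 to compound 4 (0.59 log units; beyond the scatter).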

Compound 4, concentration for total growth inhibition: 2810 nM
For compound 4 the middle estimate is 18-fold (1.25 log units) above the measured one, and the stated range ends above it.
By their numbers in this assay, from the lowest: compounds 4 and 1 (each within the scatter of the next); then compounds 2 and 3 (each within the scatter of the next).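

On the core of compound 2, chloro in place of hydrogen on an aromatic carbon between two ring nitrogen atoms strengthens growth inhibition in this assay, with a 4.6-fold lower number from compound 2 to compound 4 (0.66 log units; beyond the scatter). Among these compounds, this is the first case in which the exchange moves the number downward, so the single earlier step no longer describes this change at this position, and the two known steps run in opposite directions, by far more than the scatter of such steps allows: the same change on two cores in this assay, a 5.8-fold higher number (0.76 log units; beyond the scatter) from compound 1 to compound 3 and a 4.6-fold lower number (0.66 log units; beyond the scatter) from compound 2 to compound 4, 26-fold (1.42 log units) apart, beyond the scatter of two such steps. Chloro at this position therefore has no single outcome across the compounds shown, and its outcome in each pair can be read only together with the rest of the molecule.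

The four compounds do not tell which feature of the rest of the molecule goes with the change of direction, and two pairs are too few to settle it. Going by these compounds, how an amine or a methoxy group at this same position would compare with hydrogen and chloro on either core also stays open.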